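Compound 1 to compound 4: methoxy to chloro

The source may report more compounds than this note shows. Statements on the series, on what has been measured and on what is new or still open speak of the compounds shown alone.

In a functional assay on NCI-H1975 cells (Homo sapiens) for cytotoxicity, read by CCK-8 assay, with a stated time of 72 h (on this read-out lower numbers stand for stronger inhibition and higher numbers for weaker inhibition), compound 1 (`COc1ccccc1/C=c1/[nH]c(=O)/c(=C\c2ccccc2OC)n(C)c1=O`) gives 16900 nM and compound 2 (`C=CCn1c(=O)/c(=C\c2ccccc2OC)[nH]c(=O)/c1=C\c1ccccc1OC`) gives 21500 nM, so the two stand level within the scatter. Compound 3 (`COc1ccccc1/C=c1/[nH]c(=O)/c(=C\c2ccccc2OC)[nH]c1=O`) gives "not active" (no number reported), without a number. Compound 4 (`COc1ccccc1/C=c1\c(=O)[nH]/c(=C/c2ccccc2Cl)c(=O)n1C`) carries chloro in place of methoxy on an aromatic carbon. For the measured compounds named here, the only measured step, a 1.3-fold higher number from compound 1 to compound 2 (0.10 log units; within the scatter), concerns a different place, a saturated chain carbon bound to an aromatic nitrogen, and no measured step touches this aromatic carbon. It offers only weak guidance, and no step beyond the scatter is expected in this assay. The expected change is a 1.1-fold lower number from compound 1 to compound 4 (0.05 log units; within the scatter). For compound 4 the estimated value is 15000 nM, with an expected range of 6000 nM to 38000 nM.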

Compound 4, half-maximal inhibitory concentration: 200 nM
Compound 4: the middle estimate sits 75-fold (1.88 log units) above what was measured, outside the stated range (below it).
By their numbers in this assay, from the lowest: compound 4; then compounds 1 and 2 (each within the scatter of the next).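

In this assay, the change from 2-methoxyphenyl to 2-chlorophenyl gives an 85-fold lower number from compound 1 to compound 4 (1.93 log units; beyond the scatter). This aromatic carbon, ortho to a large group, is therefore far more sensitive to substitution than the saturated chain carbon bound to an aromatic nitrogen, where the earlier step, a 1.3-fold higher number from compound 1 to compound 2 (0.10 log units; within the scatter), stayed within the scatter. No available evidence accounts for the size of this step. The compounds shown leave open whether the result depends on chloro itself or on the loss of methoxy; bromo, methyl or an amine at this carbon would help separate the two.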